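Methylsulfanyl to piperidin-1-yl on the shared core

The compounds below may be only part of what the source reports. "The series", "measured", "known", "first", "only" and "open" are said of these compounds alone.

Compound 1 (`CSc1nc(Cl)c(C(=O)c2ccccc2)s1`): (> 100000 nM), a limit, not a number
Compound 2 (`COC(=O)c1sc2nc(SC)sc2c1C`): (78000 nM)

All readings here come from a functional assay on A549 cells (Homo sapiens) for cytotoxicity, read by MTT assay, with a stated time of 72 h (a higher number here means a weaker inhibitor, a lower number a stronger inhibitor), and nothing else has been measured so far. For the measured compounds named here, compound 2 gives (78000 nM), and this is the only actual number. Compound 1 reaches only the limit of the assay (> 100000 nM), so it offers no number to compare.

The next compound is compound 3 (`COC(=O)c1sc2nc(N3CCCCC3)sc2c1C`), which carries piperidin-1-yl in place of methylsulfanyl on an aromatic carbon. The swap sits on the five-membered aromatic ring, next to the ring nitrogen and next to the ring sulfur.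

Going by the values given here, no measured step covers this change, so the expectation is anchored only on compound 2 (78000 nM) and remains loose. The expected step is (a 1.7-fold lower number from compound 2 to compound 3 (0.24 log units; within the scatter)), a small one toward a stronger inhibitor and not clearly beyond the usual scatter. A reading at the limit of the assay also remains possible. The estimated value for compound 3 is (45000 nM), within an expected range of (12000 nM to 100000 nM).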

Compound 3, half-maximal inhibitory concentration: > 100000 nM
Compound 3 gave a limit, no number; the forecaster's own chance of this, stated with the estimate: 20%; middle value at least 2.2-fold (0.34 log units) away from the limit.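

In this assay, piperidin-1-yl in place of methylsulfanyl on this aromatic carbon gives an at least 1.2-fold higher number from compound 2 to compound 3 (0.10 log units; that floor lies within the scatter), the first step the series offers at this position. That figure is only a floor, so the change shows no gain here, but it cannot be called a loss beyond the usual scatter. The true size of the step cannot be read because the reading for compound 3 is a limit and not a number: the limit of > 100000 nM in this assay, at which 2 of the 3 values shown sit.

Still open, from the compounds shown here alone, is how far methylsulfanyl can be exchanged on this carbon at all, and whether a small open-chain amine such as dimethylamino, or a morpholin-4-yl ring, would give a number rather than a limit. The shown compounds also leave open whether the methyl ester of compound 2 matters, which a carboxylic acid or a primary amide in its place would begin to test.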